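The compounds below may be only part of what the source reports. "The series", "measured", "known", "first", "only" and "open" are said of these compounds alone.

Working notes on the sulfonamide series.

Compound 1 `CCc1ccccc1NS(=O)(=O)c1ccc(N2CCNC2=O)cc1` is the reference point. In a functional assay on MCF7 cells (Homo sapiens) for antiproliferative activity, read by sulforhodamine B assay, with a stated time of 48 h (a higher number here means a weaker inhibitor, a lower number a stronger inhibitor), compound 1 gives 350 nM, the lowest of the three numbers recorded so far. Compound 2 `CCc1ccc(NS(=O)(=O)c2ccc(N3CCNC3=O)cc2)cc1` gives 810 nM and compound 3 `COc1ccccc1NS(=O)(=O)c1ccc(N2CCNC2=O)cc1` gives 770 nM; both sit above compound 1, with a 2.3-fold higher number from compound 1 to compound 2 (0.36 log units; beyond the scatter) and a 2.2-fold higher number from compound 1 to compound 3 (0.34 log units; beyond the scatter), while the pair compound 2 and compound 3 show a 1.1-fold lower number from compound 2 to compound 3 (0.02 log units; within the scatter).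

Compound 4 `COc1cccc(NS(=O)(=O)c2ccc(N3CCNC3=O)cc2)c1` has not been measured. Relative to compound 1 the change is 3-methoxyphenyl in place of 2-ethylphenyl on a sulfonamide nitrogen. Two recorded steps bear on it. Moving the ethyl from 2-ethylphenyl to 4-ethylphenyl gave a modest rise in the number from compound 1 to compound 2, and swapping ethyl for methoxy on the aromatic carbon gave a similar modest rise from compound 1 to compound 3. Among the compounds with values here, compound 4 combines a move of the substituent away from the arrangement of compound 1 with the methoxy in place of ethyl, so a modest rise beyond the scatter is expected, not a fall; a larger effect cannot be excluded, since no 3-substituted analogue is on record.

For compound 4 the expected step is a 2.6-fold higher number from compound 1 to compound 4 (0.41 log units; beyond the scatter), giving an estimate of 900 nM with a range of 400 nM to 2200 nM.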

Compound 4, half-maximal inhibitory concentration: 120 nM
The estimate for compound 4 lay 7.5-fold (0.88 log units) above the measured number; the measured number lies below the stated range.
By their numbers in this assay, from the lowest: compound 4; then compound 1; then compounds 3 and 2 (each within the scatter of the next).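

Within the data shown here, compound 4 is the first compound to fall below the reference, with a 2.9-fold lower number from compound 1 to compound 4 (0.46 log units; beyond the scatter), whereas both earlier steps from compound 1 raised the number. On a sulfonamide nitrogen the methoxy group therefore does not carry a penalty of its own: 3-methoxyphenyl in place of 2-methoxyphenyl gives a 6.4-fold lower number from compound 3 to compound 4 (0.81 log units; beyond the scatter), so two isomeric methoxyphenyl groups on the same core separate clearly, and the rise seen with compound 3 cannot be read as a general effect of methoxy in place of ethyl. 3-Methoxyphenyl in place of 4-ethylphenyl gives a 6.8-fold lower number from compound 2 to compound 4 (0.83 log units; beyond the scatter), which places 3-methoxyphenyl beyond the scatter from all three other groups in this series.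

The compounds shown leave open whether the lower number belongs to the methoxy group or to its place on the ring, which 3-ethylphenyl would help to separate, and whether a longer chain such as 3-propoxyphenyl or an amine such as 3-aminophenyl would keep it. No evidence at hand bears on why 3-methoxyphenyl stands apart from the other groups.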